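Swapping the aryl group on a pyridazinone amide series

This account rests on a few compounds, and the source may have more. Where it says the series, first, only, none or still open, it means among the compounds named here.

Of the compounds shown here, three sharing one core have been measured in a functional assay on HepG2 cells (Homo sapiens) for cytotoxicity, read by MTT assay, with a stated time of 72 h; on this read-out higher numbers stand for weaker inhibition and lower numbers for stronger inhibition. Compound 1 `Cc1cc(=O)n(-c2ccc(Br)cc2F)nc1C(=O)Nc1ccc(Oc2ncnc3ccsc23)cc1` gives 10600 nM in this assay. Compound 2 `Cc1cc(=O)n(-c2cccc(F)c2)nc1C(=O)Nc1ccc(Oc2ncnc3ccsc23)cc1` gives 10200 nM in this assay, and compound 3 `Cc1cc(=O)n(-c2ccc(F)c(F)c2)nc1C(=O)Nc1ccc(Oc2ncnc3ccsc23)cc1` gives 9230 nM in this assay. Compound 3 thus has the lowest of the three numbers, but the steps of a 1.1-fold lower number from compound 1 to compound 3 (0.06 log units; within the scatter) and a 1.1-fold lower number from compound 2 to compound 3 (0.04 log units; within the scatter) both lie within the scatter, as does a 1.0-fold lower number from compound 1 to compound 2 (0.02 log units; within the scatter). Compound 4 `Cc1ccc(-n2nc(C(=O)Nc3ccc(Oc4ncnc5ccsc45)cc3)c(C)cc2=O)c(C)c1` carries 2,4-dimethylphenyl in place of 3,4-difluorophenyl on an aromatic nitrogen. Among the compounds with values here, no measured step matches this exchange directly, yet every change of the aryl group so far left this assay unmoved, so compound 4 is expected to show a 1.1-fold higher number from compound 3 to compound 4 (0.03 log units; within the scatter), a step of no real size. The estimate for compound 4 in this assay is therefore 10000 nM, with a range from 4000 nM to 25000 nM.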

Compound 4, half-maximal inhibitory concentration: 17900 nM
Estimate against measurement, compound 4: 1.8-fold (0.25 log units) below, within the range that was stated.
By their numbers in this assay, from the lowest: compounds 3, 2, 1 and 4 (each within the scatter of the next).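

In this assay the move to an aryl group with no halogen stays small: a 1.9-fold higher number from compound 3 to compound 4 (0.29 log units; within the scatter) and a 1.8-fold higher number from compound 2 to compound 4 (0.24 log units; within the scatter) and a 1.7-fold higher number from compound 1 to compound 4 (0.23 log units; within the scatter) all lie within the scatter. On this aromatic nitrogen, 2,4-dimethylphenyl, whose heavy atoms are all carbon, thus stands level with the aryl groups of compounds 1, 2 and 3, so halogen on this ring is not required for this level of cytotoxicity. Nothing at hand explains this result. From the compounds shown here alone, whether an aryl group carrying an amine or a carboxylic acid would shift the number stays open.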